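The source may report more compounds than this note shows. Statements on the series, on what has been measured and on what is new or still open speak of the compounds shown alone.

Working notes on a short series sharing one core, varied only in the aryl group on the saturated ring carbon and in the halogen on that aryl group.

Compound 1 `CN1C(=O)C(c2cccc(F)c2)N(C)c2nc(Nc3ccc(S(N)(=O)=O)cc3)ncc21` gives, in an assay on Sf9 cells for inhibition of serine/threonine-protein kinase 4 (Homo sapiens), read by luminescence and ADP-Glo, with a stated time of 1 h, in the presence of a further agent that is not named here (a higher number here means a weaker inhibitor, a lower number a stronger inhibitor), a value of 134 nM. Compound 2 `CN1C(=O)C(c2cccc(Cl)c2)N(C)c2nc(Nc3ccc(S(N)(=O)=O)cc3)ncc21` gives in this assay a value of 989 nM, and compound 3 `CN1C(=O)C(c2ccccc2F)N(C)c2nc(Nc3ccc(S(N)(=O)=O)cc3)ncc21` gives in this assay a value of 75 nM. The steps between them: a 7.4-fold higher number from compound 1 to compound 2 (0.87 log units; beyond the scatter); a 1.8-fold lower number from compound 1 to compound 3 (0.25 log units; within the scatter); a 13-fold lower number from compound 2 to compound 3 (1.12 log units; beyond the scatter).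

The change from compound 1 to compound 2 is chloro in place of fluoro on an aromatic carbon. The still unmeasured compound 4 `CN1C(=O)C(c2ccccc2Cl)N(C)c2nc(Nc3ccc(S(N)(=O)=O)cc3)ncc21` is reached from compound 3 by chloro in place of fluoro on an aromatic carbon. These are the same kind of change, not the same change: in compound 2 the chloro sits meta to a large group, in compound 4 ortho to a large group. The two cores differ as 2-fluorophenyl in place of 3-fluorophenyl on a saturated ring carbon.

Among the measured compounds shown here, with only one measured instance of this kind of change, the expectation for compound 4 rests on the step from compound 1 to compound 2, a 7.4-fold higher number from compound 1 to compound 2 (0.87 log units; beyond the scatter), tempered by the different place on the ring. The step expected from compound 3 to compound 4 in this assay is a 4.0-fold higher number from compound 3 to compound 4 (0.60 log units; beyond the scatter), somewhat smaller than the earlier one. Compound 4 is therefore expected to give about 300 nM in this assay, with a plausible range from 100 nM to 900 nM.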

Compound 4, half-maximal inhibitory concentration: 129 nM
The estimate for compound 4 lay 2.3-fold (0.37 log units) above the measured number, within the range that was stated.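

In this assay, chloro in place of fluoro on an aromatic carbon does not carry over from one core to the other at the same size: the same change on two cores in this assay, a 7.4-fold higher number (0.87 log units; beyond the scatter) from compound 1 to compound 2 and a 1.7-fold higher number (0.24 log units; within the scatter) from compound 3 to compound 4, 4.3-fold (0.63 log units) apart, beyond the scatter of two such steps

With the halogen ortho to a large group, the exchange gives a 1.7-fold higher number from compound 3 to compound 4 (0.24 log units; within the scatter), so it is not resolved there, while the change from 3-chlorophenyl to 2-chlorophenyl gives a 7.7-fold lower number from compound 2 to compound 4 (0.88 log units; beyond the scatter), and the chloro penalty seen on the core of compound 1 therefore does not hold on the 2-substituted aryl group. The comparison a 1.0-fold lower number from compound 1 to compound 4 (0.02 log units; within the scatter) spans two changes at once and adds nothing about either of them, and two pairs show only that the size of this exchange depends on the core; they give no rule for other halogens or other ring places, and no reason for the difference.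

The compounds shown leave open how an unsubstituted phenyl, or a methoxy, nitrile or amine on the aryl group, would read in this assay. They also leave open whether the difference between the two cores persists when the sulfonamide is replaced, for instance by a carboxylic acid.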